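Ethyl in place of ethynyl: one small change on compound 1

This account rests on a few compounds, and the source may have more. Where it says the series, first, only, none or still open, it means among the compounds named here.

Compound 1 `C#Cc1cc(-c2csc(Nc3cccc(C)c3)n2)ccn1` is a weak inhibitor in a functional assay on RCC4 cells (Homo sapiens) for inhibition, read by XTT assay, with a stated time of 4 days (on this read-out higher numbers stand for weaker inhibition and lower numbers for stronger inhibition), where compound 1 gives 18200 nM. That is the only number shown for compound 1, and it stands close to compound 2 `Cc1cccc(Nc2nc(-c3ccnc(-c4ccccc4)c3)cs2)c1`, which in this assay gives 19100 nM; 19500 nM (2 entries). The repeated entries of compound 2 (the several entries of compound 2 in this assay, 19100 nM; 19500 nM (2 entries)) show how closely readings of this kind agree, and the values of compound 1 and compound 2 lie within the usual scatter of each other.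

Compound 3 `CCc1cc(-c2csc(Nc3cccc(C)c3)n2)ccn1` differs from compound 1 in one place: ethyl in place of ethynyl on an aromatic carbon. Within the data shown here, no measured pair shows the effect of exactly this change, so there is no measured step to lean on. Both measured compounds sit in the same weak range, and a swap of two small carbon groups is not expected to shift the reading by more than the scatter. Compound 3 is therefore expected to give about 18000 nM, with a range from 8000 nM to 40000 nM. The expected step of a 1.0-fold lower number from compound 1 to compound 3 (0.00 log units; within the scatter) amounts to none beyond the scatter.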

Compound 3, half-maximal inhibitory concentration: 6460 nM
The estimate for compound 3 lay 2.8-fold (0.45 log units) above the measured number; the measured number lies below the stated range.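

In this assay, putting ethyl in place of ethynyl gives a 2.8-fold lower number from compound 1 to compound 3 (0.45 log units; beyond the scatter), so the lower number means stronger inhibition, although the gain is modest. This shows that the position on the aromatic carbon next to the ring nitrogen responds to a very small edit: both groups have 2 heavy atoms, both carbon, with no ring, no hydrogen-bond donors or acceptors and no net charge, and the counted difference is the triple bond that leaves with ethynyl. The step is larger than the disagreement between repeated readings, as seen here: the several entries of compound 2 in this assay, 19100 nM; 19500 nM (2 entries)

As far as these compounds go, a single pair cannot say why ethyl reads better than ethynyl, or whether the triple bond itself matters, so the reason for the step stays unknown. Nor do the compounds shown reveal whether a longer chain such as propyl, a smaller group such as methyl, or an amine at this same position would lower the number further or raise it again.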